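The compounds below may be only part of what the source reports. "The series", "measured", "known", "first", "only" and "open" are said of these compounds alone.

The three measured compounds, with their values in a functional assay on SK-BR-3 cells (Homo sapiens) for antiproliferative activity, read by MTT assay, with a stated time of 72 h; a lower number here means a stronger inhibitor, a higher number a weaker inhibitor:

Compound 1 `CCN1CCN(c2cc(C)c3cc(NC(=O)c4cccc(Cl)c4)ccc3n2)CC1`: 17800 nM
Compound 2 `CCN1CCN(c2cc(C)c3cc(NC(=O)c4ccccc4C)ccc3n2)CC1`: 29200 nM
Compound 3 `Cc1cc(NCCN2CCN(C)CC2)nc2ccc(NC(=O)c3ccc(Cl)c(Cl)c3)cc12`: 2690 nM

Compound 2 has the highest number of the three in this assay. Its nearest neighbour is compound 1, whose value is lower by a margin that stays within the scatter; compound 3 lies furthest away, with a number lower by a gap well beyond it. Compound 3 also differs from compound 2 in more than one place, so its value is noted only as a reference point.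

Compound 4 `CCN1CCN(c2cc(C)c3cc(NC(=O)c4ccc(Cl)cc4)ccc3n2)CC1` is not yet measured. It differs from compound 2 in one place: 4-chlorophenyl in place of 2-methylphenyl on a carbonyl carbon.

Going by the values given here, one measured step bears on this change. Going from compound 1 to compound 2, the 2-methylphenyl took the place of a 3-chlorophenyl and gave a 1.6-fold higher number from compound 1 to compound 2 (0.21 log units; within the scatter). Compound 4 returns a chlorine-bearing ring, now the 4-chlorophenyl, so the step back is expected to be small and, if anything, toward a lower number, while staying within the scatter.

On that basis compound 4 is expected to give about 16000 nM in this assay, with a plausible range from 6500 nM to 40000 nM, which corresponds to an expected step of a 1.8-fold lower number from compound 2 to compound 4 (0.26 log units; within the scatter).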

Compound 4, half-maximal inhibitory concentration: 3020 nM
The estimate for compound 4 lay 5.3-fold (0.72 log units) above the measured number; measured number below the stated range.
By their numbers in this assay, from the lowest: compounds 3 and 4 (each within the scatter of the next); then compounds 1 and 2 (each within the scatter of the next).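

In this assay, going by these compounds alone, the group on the carbonyl carbon can move the number well beyond the scatter: 4-chlorophenyl in place of 2-methylphenyl gave a 9.7-fold lower number from compound 2 to compound 4 (0.99 log units; beyond the scatter), whereas the only earlier step at this place stayed within it. Where the chlorine sits on the phenyl ring also matters, since 4-chlorophenyl in place of 3-chlorophenyl gave a 5.9-fold lower number from compound 1 to compound 4 (0.77 log units; beyond the scatter), so carrying a chlorine is not enough on its own, as the earlier step between the 3-chlorophenyl and 2-methylphenyl groups had already hinted. Nothing available here accounts for why the 4-chlorophenyl group behaves differently from the other two groups.

With only one 4-substituted phenyl group among these compounds, it remains open whether the lower number depends on the chlorine itself or would also appear with another group in its place, such as 4-methylphenyl, 4-methoxyphenyl or 4-fluorophenyl. Going by these compounds, it is also open whether the same step would hold with a different amine on the core, such as the methylpiperazinyl-ethylamine chain of compound 3.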